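Does 4-ethylphenyl restore growth inhibition?

The source may hold more compounds than are shown below. What is called first, only, known or untested is meant among the compounds shown, and "the series" means these compounds.

Among the compounds with values here, in a functional assay on A498 cells (Homo sapiens) for inhibition, read by sulforhodamine B assay, with a stated time of 48 h (on this read-out higher numbers stand for weaker inhibition of growth and lower numbers for stronger inhibition of growth), compound 2 `Cc1cc(O)ccc1C1=NN(c2ccc(S(C)(=O)=O)cc2)C(=O)CC1` reads 2780 nM and stands highest of the two numbers so far, while compound 1 `Cc1ccc(C2=NN(c3ccc(S(C)(=O)=O)cc3)C(=O)CC2)cc1` reads 140 nM as the stronger inhibitor. Compound 3 `CCc1ccc(C2=NN(c3ccc(S(C)(=O)=O)cc3)C(=O)CC2)cc1` carries 4-ethylphenyl in place of 4-hydroxy-2-methylphenyl on a carbon with a double bond to nitrogen on a carbon with a double bond to nitrogen. Within the data shown here, the one measured step bearing on this, a 20-fold higher number from compound 1 to compound 2 (1.30 log units; beyond the scatter) with 4-hydroxy-2-methylphenyl in place of 4-methylphenyl, was large, so a large step back toward stronger inhibition is expected. The estimated change is an 11-fold lower number from compound 2 to compound 3 (1.05 log units; beyond the scatter) in the downward direction. Compound 3 is expected at 250 nM with a range from 80 nM to 800 nM as the estimated span.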

Compound 3, concentration for 50% growth inhibition: 140 nM
Beside the measured number, compound 3's estimate is 1.8-fold (0.25 log units) above it; the measured number falls inside the stated range.
By their numbers in this assay, from the lowest: compounds 1 and 3 (each within the scatter of the next); then compound 2.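

In this assay, the change to 4-ethylphenyl gives a 20-fold lower number from compound 2 to compound 3 (1.30 log units; beyond the scatter), while the one-carbon extension of the methyl of compound 1 gives no change at the digits printed from compound 1 to compound 3 (within the scatter). At this position, then, 4-methylphenyl and 4-ethylphenyl read alike, so the first chain extension shown leaves growth inhibition unchanged. Nothing measured here explains why these two groups differ from 4-hydroxy-2-methylphenyl. Still open, going by these compounds, is whether a longer chain such as propyl, or an amine on the same phenyl ring, would keep this level. Also open is which feature of 4-hydroxy-2-methylphenyl accounts for the higher number of compound 2.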